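The source may hold more compounds than are shown below. What is called first, only, known or untested is meant among the compounds shown, and "the series" means these compounds.

Three amides built on one shared core have been measured in an assay on HEK293 cells for inhibition of transient receptor potential cation channel subfamily V member 1 (Homo sapiens); a higher number here means a weaker inhibitor, a lower number a stronger inhibitor. Compound 1 `CCCCCCCCC(=O)NCc1cc(I)c(O)c(OC)c1` gives 126 nM in this assay. Compound 2 `CCCCCCCCC(=O)NCc1ccc(O)c(OC)c1I` gives 3380 nM in this assay. Compound 3 `CCCCCCCCC(=O)NCc1cc(OC)c(O)cc1Br` gives 16.1 nM in this assay, the lowest number of the three; its gaps to compound 1 and to compound 2 both lie beyond the scatter. The three structures differ from one another at more than one place, so none of these gaps can be tied to a single change.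

Compound 4 `CCCCCCCCC(=O)NCc1cc(OC)c(O)cc1Cl` has not yet been measured. It differs from compound 3 by chloro in place of bromo on an aromatic carbon. Among the compounds with values here, no measured pair differs by this exchange alone, so the data give no direct reading of its effect. The expected step from compound 3 to compound 4 is a 1.6-fold higher number from compound 3 to compound 4 (0.19 log units; within the scatter), a small move toward a weaker inhibitor that may well sit within the scatter. Compound 4 is estimated at 25 nM, with a range from 8 nM to 80 nM.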

Compound 4, half-maximal inhibitory concentration: 50.3 nM
For compound 4 the middle estimate is 2.0-fold (0.30 log units) below the measured one; the measured number falls inside the stated range.
By their numbers in this assay, from the lowest: compound 3; then compound 4; then compound 1; then compound 2.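

Chloro in place of bromo on this aromatic carbon, para to a methoxy group, gives the first step in the series that can be tied to a single change: in this assay it is a 3.1-fold higher number from compound 3 to compound 4 (0.49 log units; beyond the scatter), modest but beyond the scatter. The choice of halogen at this position therefore registers in the read-out, and bromo gives the lower number of the two. No measurement at hand accounts for this difference.

With only two halogens compared at this position, no trend can be drawn; fluoro, iodo or a methyl group on the same carbon could fall on either side of this pair. On these data alone, it also remains open whether the step would keep its size with a longer chain in place of the present one.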